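The source may report more compounds than this note shows. Statements on the series, on what has been measured and on what is new or still open speak of the compounds shown alone.

Measured compounds:
compound 1 `CC1(C)C(=O)NC(c2ccc(N)cc2)c2ccccc21` — 240 mg/kg
compound 2 `CCCNCC(=O)Nc1ccc(C2NC(=O)C(C(C)C)c3ccccc32)cc1` — 50 mg/kg
compound 3 `CC(C)C1C(=O)NC(c2ccc(NC(=O)CCCN3CCCC3)cc2)c2ccccc21` — 86 mg/kg

All three were tested in a toxicity assay on the whole organism with Mus musculus as the target, in the rotarod test; on this read-out higher numbers stand for an effect only at larger amounts of compound and lower numbers for an effect already at smaller amounts. Compound 1 gives the highest of the three numbers; compound 3 comes nearest, and compound 2 lies furthest away. Compounds 2 and 3 carry an amide-bearing side chain on the aromatic nitrogen, and both give lower numbers than compound 1, which carries a free hydrogen there, although the two also differ from compound 1 in the group on the shared core.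

Compound 4 `CC1(C)C(=O)NC(c2ccc(NC(=O)CN3CCCCC3)cc2)c2ccccc21` has not yet been measured. Its difference from compound 1 is ((piperidin-1-yl)methyl)carbonyl in place of hydrogen on a nitrogen on an aromatic ring. Within the data shown here, the only measured step, a 1.7-fold higher number from compound 2 to compound 3 (0.24 log units; within the scatter), changes the tail of such a side chain and is within the scatter, so the kind of tail seems to matter little. Among the measured compounds shown here, no measured pair isolates the addition of the side chain itself. The values of compounds 2 and 3, both lower than compound 1, suggest that attaching the side chain is expected to lower the number, so a step of roughly a 2.5-fold lower number from compound 1 to compound 4 (0.40 log units; beyond the scatter) is estimated for this assay. Compound 4 is therefore expected to give about 95 mg/kg, within a range from 45 mg/kg to 200 mg/kg.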

Compound 4, dose for half-maximal effect: > 2000 mg/kg
Compound 4 was reported as a limit; the forecaster's own chance of this, stated with the estimate: 5%; middle value at least 21-fold (1.32 log units) from the limit.
By their numbers in this assay, from the lowest: compounds 2 and 3 (each within the scatter of the next); then compound 1. At a limit, above all of these: compound 4.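

Compound 1 and compound 4 differ in one place only, so this pair isolates the effect of ((piperidin-1-yl)methyl)carbonyl in place of hydrogen on a nitrogen on an aromatic ring, and in this assay it gives an at least 8.3-fold higher number from compound 1 to compound 4 (0.92 log units; beyond the scatter). For compound 4, the value of > 2000 mg/kg is a limit of the assay and not a number, and it stands alone there: the limit of > 2000 mg/kg in this assay, at which 1 of the 4 values shown sits. On the core of compound 1, then, filling this nitrogen with the side chain moves the effect to larger amounts of compound, something compounds 2 and 3 could not show, as each differs from compound 1 in more than one place.

From the compounds shown here alone, whether this holds for the side chain as a whole or depends on the piperidine ring stays open; a plain acetyl group on the same nitrogen, or a morpholine ring or a dimethylamino group in place of the piperidine ring, would help to separate the two. Also open, going by these compounds, is whether the same side chain would act alike on the core of compound 2, which carries a different group.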